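Fluoro to Trifluoromethyl on Compound 2

This account rests on a few compounds, and the source may have more. Where it says the series, first, only, none or still open, it means among the compounds named here.

In a functional assay on HepG2 cells (Homo sapiens) for antiproliferative activity, read by MTT assay, with a stated time of 24 h (on this read-out higher numbers stand for weaker inhibition and lower numbers for stronger inhibition), compound 1 (`COc1ccc(S(=O)(=O)n2c(-c3cn(-c4ccccc4)nc3-c3ccc(F)cc3)nc3ccccc32)cc1`) gives 470 nM, compound 2 (`O=[N+]([O-])c1ccc(S(=O)(=O)n2c(-c3cn(-c4ccccc4)nc3-c3ccc(F)cc3)nc3ccccc32)cc1`) gives 1340 nM and compound 3 (`O=S(=O)(c1ccc(Cl)cc1)n1c(-c2cn(-c3ccccc3)nc2-c2ccc(F)cc2)nc2ccccc21`) gives 4230 nM, which leaves compound 2 in the middle of the three. Compound 4 (`O=[N+]([O-])c1ccc(S(=O)(=O)n2c(-c3cn(-c4ccccc4)nc3-c3ccc(C(F)(F)F)cc3)nc3ccccc32)cc1`) carries trifluoromethyl in place of fluoro on an aromatic carbon. Going by the values given here, no measured step touches this place. The nearest guides are swaps at another aromatic carbon, a 2.9-fold higher number from compound 1 to compound 2 (0.46 log units; beyond the scatter) and a 3.2-fold higher number from compound 2 to compound 3 (0.50 log units; beyond the scatter), both modest. They suggest that one swap can matter, but they say little about direction. A modest rise is therefore expected, tentatively, as a 1.3-fold higher number from compound 2 to compound 4 (0.13 log units; within the scatter). For compound 4 the estimated value is 1800 nM, within an expected range from 600 nM to 5500 nM.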

Compound 4, half-maximal inhibitory concentration: 1070 nM
The estimate for compound 4 lay 1.7-fold (0.23 log units) above the measured number; measured number inside the range.
By their numbers in this assay, from the lowest: compound 1; then compounds 4 and 2 (each within the scatter of the next); then compound 3.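

This first change at the fluoro-bearing aromatic carbon, 4-fluorophenyl to 4-(trifluoromethyl)phenyl, gives a 1.3-fold lower number from compound 2 to compound 4 (0.10 log units; within the scatter) in this assay, so the two compounds cannot be told apart here. Unlike the earlier swaps of methoxy, nitro and chloro, which moved the number beyond the scatter, this swap shows that a group with more heavy atoms can stand at this place without a clear shift. No measurement shown explains this result. Going by these compounds, whether an amine or a carboxylic acid would be tolerated here remains open. So does whether trifluoromethyl would behave alike with methoxy in place of nitro.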